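Moving the chlorine on a weakly cytotoxic triazine amide

The source may report more compounds than this note shows. Statements on the series, on what has been measured and on what is new or still open speak of the compounds shown alone.

Compound 1 `O=C(CN1CCN(c2ccc(Cl)cc2)CC1)N1CCN(c2nnc(-c3ccccc3)c(-c3ccccc3)n2)CC1`: 113000 nM
Compound 2 `Cc1ccc(-c2nnc(N3CCN(C(=O)CN4CCN(c5ccccc5Cl)CC4)CC3)nc2-c2ccc(C)cc2)cc1`: > 859000 nM

In an ADME assay on NIH3T3 cells (Mus musculus) for cytotoxicity, read by MTT assay, with a stated time of 24 h (a higher number here means a weaker inhibitor, a lower number a stronger inhibitor), compound 1 gives 113000 nM. For compound 2 this assay reports only a limit, > 859000 nM, which is the limit of > 859000 nM in this assay, at which 1 of the 2 values shown sits. Of the two values shown, compound 2 is thus the one sitting at the limit, not at a number. Compound 3 `Cc1ccc(-c2nnc(N3CCN(C(=O)CN4CCN(c5ccc(Cl)cc5)CC4)CC3)nc2-c2ccc(C)cc2)cc1` differs from it by 4-chlorophenyl in place of 2-chlorophenyl on an amine nitrogen in a ring. Going by the values given here, no measured pair isolates this change, so the step is expected to be small, with an at least 1.7-fold lower number from compound 2 to compound 3 (0.23 log units; that floor lies within the scatter) expected to lie within the usual scatter. Compound 3 is therefore estimated at 500000 nM, between 150000 nM and 1500000 nM.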

Compound 3, half-maximal inhibitory concentration: 567000 nM
Compound 3: middle estimate off by 1.1-fold (0.05 log units), on the low side; measured number inside the range.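

Going by these compounds alone, compound 2 and compound 3 form the first pair that isolates a single change, 4-chlorophenyl in place of 2-chlorophenyl on an amine nitrogen in a ring, and in this assay the step reads an at least 1.5-fold lower number from compound 2 to compound 3 (0.18 log units; that floor lies within the scatter). The true size of this step cannot be read, because the value for compound 2 is a limit and not a number: the limit of > 859000 nM in this assay, at which 1 of the 3 values shown sits. Compound 3 gives this position its first measured number in this series, 567000 nM.

What the compounds shown leave open is how this assay responds when an amine or a carboxylic acid replaces the chlorine on that phenyl ring.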